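Methylsulfonyl for benzyloxycarbonyl on compound 3

The compounds below may be only part of what the source reports. "The series", "measured", "known", "first", "only" and "open" are said of these compounds alone.

In a functional assay on A549 cells (Homo sapiens) for antiproliferative activity, read by sulforhodamine B assay, with a stated time of 72 h (on this read-out higher numbers stand for weaker inhibition and lower numbers for stronger inhibition), compound 1 (`COc1cc(/C=C2\CCC=CC2=O)cc(OC)c1`) gives 4740 nM and compound 2 (`Cn1cc(/C=C2\CCC=CC2=O)c2ccccc21`) gives 4920 nM within the scatter of each other. Compound 3 (`COc1cc(/C=C2\CN(C(=O)OCc3ccccc3)C=CC2=O)cc(OC)c1OC`) gives 21300 nM as the highest of the three numbers, the weakest inhibition here, beyond the scatter from both others. Compound 4 (`COc1cc(/C=C2\CN(S(C)(=O)=O)C=CC2=O)cc(OC)c1OC`) has methylsulfonyl in place of benzyloxycarbonyl on an amine nitrogen in a ring. Going by the values given here, no measured pair shows this change, so the step in this assay is a judgement: a moderate move towards stronger inhibition is expected, since compound 2 at 4920 nM carries no benzyloxycarbonyl. The expected step is a 2.4-fold lower number from compound 3 to compound 4 (0.37 log units; beyond the scatter) on this estimate. The estimate for compound 4 is 9000 nM (3000 nM to 27000 nM).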

Compound 4, half-maximal inhibitory concentration: 18700 nM
The estimate for compound 4 lay 2.1-fold (0.32 log units) below the measured number; the range from low to high includes it.
By their numbers in this assay, from the lowest: compounds 1 and 2 (each within the scatter of the next); then compounds 4 and 3 (each within the scatter of the next).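

In this assay, the direct reading at this amine nitrogen in a ring is a 1.1-fold lower number from compound 3 to compound 4 (0.06 log units; within the scatter), so methylsulfonyl in place of benzyloxycarbonyl leaves the two compounds within the scatter of each other. Losing the six-membered aromatic ring of carbon only, and going from 10 heavy atoms to 4, therefore separates neither compound from the other in this assay. No measurement available here explains this flat step. Still open, on these data alone, is whether an acetyl group or a free amine hydrogen on this nitrogen would give a step beyond the scatter.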